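Compound 2 to compound 3: diethylamino to hydroxy

This account rests on a few compounds, and the source may have more. Where it says the series, first, only, none or still open, it means among the compounds named here.

Values so far in a functional assay on BXPC-3 cells (Homo sapiens) for antiproliferative activity, read by MTT assay, with a stated time of 24 h; on this read-out higher numbers stand for weaker inhibition and lower numbers for stronger inhibition
compound 1 `CCn1c(C(=O)NCC(=O)OC)ccc1C(CC)(CC)c1ccc(OCS(=O)(=O)c2ccccc2)c(C)c1` gives 20000 nM
compound 2 `CCN(CC)CCNC(=O)c1ccc(C(CC)(CC)c2ccc(OCS(=O)(=O)c3ccccc3)c(C)c2)n1CC` gives 6270 nM

Compound 2 at 6270 nM holds the lower of the two numbers. Compound 3 `CCn1c(C(=O)NCCO)ccc1C(CC)(CC)c1ccc(OCS(=O)(=O)c2ccccc2)c(C)c1` has hydroxy in place of diethylamino on a saturated chain carbon, two bonds along the chain from an amide-type nitrogen. Among the compounds with values here, one measured step bears on this, the modest 3.2-fold lower number from compound 1 to compound 2 (0.50 log units; beyond the scatter) which introduced the diethylamino group. Compound 3 lacks that group, as does compound 1 at 20000 nM and a move back towards weaker inhibition is expected. The estimated change is a 2.2-fold higher number from compound 2 to compound 3 (0.35 log units; beyond the scatter) in this assay and is expected to be of similar or smaller size than that one step. For compound 3 the estimate is 14000 nM with an expected range of 5000 nM to 35000 nM.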

Compound 3, half-maximal inhibitory concentration: 19900 nM
For compound 3 the middle estimate is 1.4-fold (0.15 log units) below the measured one; measured number inside the range.
By their numbers in this assay, from the lowest: compound 2; then compounds 3 and 1 (each within the scatter of the next).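

In this assay, hydroxy in place of diethylamino on this saturated chain carbon gives a clear loss (a 3.2-fold higher number from compound 2 to compound 3 (0.50 log units; beyond the scatter)), so the lower number of compound 2 does not carry over to a hydroxy-ended chain. The hydroxy-ended chain of compound 3 and the ester-ended chain of compound 1 do not separate (a 1.0-fold lower number from compound 1 to compound 3 (0.00 log units; within the scatter)), leaving the diethylamino-ended chain of compound 2 as the only one of the three that stands apart. No measurement shown accounts for this difference.

Going by these compounds, whether another amine, such as dimethylamino or pyrrolidine, would match compound 2 remains open. So does the effect of a longer chain carrying the diethylamino group.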